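A few compounds are considered here, and "the series" means these few. Any claim that something is new, unique, unknown or untested is made for them only; others in the source may bear on it.

Going by the values given here, in a functional assay on HT-29 cells (Homo sapiens) for antiproliferative activity, read by sulforhodamine B assay, with a stated time of 48 h (a lower number here means a stronger inhibitor, a higher number a weaker inhibitor), three compounds that share one core have numbers so far. Compound 1 `Cc1ccc(NS(=O)(=O)c2ccc(N3CCNC3=O)cc2)cc1` gives 480 nM, compound 2 `CCc1cccc(NS(=O)(=O)c2ccc(N3CCNC3=O)cc2)c1` gives 110 nM and compound 3 `O=C1NCCN1c1ccc(S(=O)(=O)Nc2ccc(Br)cc2)cc1` gives 300 nM. Compound 3 stands close to one of the others and apart from the other: the data show a 1.6-fold lower number from compound 1 to compound 3 (0.20 log units; within the scatter), and also a 2.7-fold higher number from compound 2 to compound 3 (0.44 log units; beyond the scatter). Compound 4 `COc1ccccc1NS(=O)(=O)c1ccc(N2CCNC2=O)cc1` has not yet been measured. It carries 2-methoxyphenyl in place of 4-bromophenyl on a sulfonamide nitrogen. Among the compounds with values here, no measured compound carries this new group, so the three measured swaps at this place are only an indirect guide. The largest of them is a 4.4-fold lower number from compound 1 to compound 2 (0.64 log units; beyond the scatter), and the steps do not all run the same way. No step beyond the scatter is therefore expected in this assay, although a modest step either way would not be surprising. The expected step is a 1.2-fold lower number from compound 3 to compound 4 (0.08 log units; within the scatter). For compound 4 the estimated value is 250 nM, with an expected range from 90 nM to 800 nM.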

Compound 4, half-maximal inhibitory concentration: 550 nM
For compound 4 the middle estimate is 2.2-fold (0.34 log units) below the measured one; the range from low to high includes it.
By their numbers in this assay, from the lowest: compound 2; then compounds 3, 1 and 4 (each within the scatter of the next).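

In this assay, going by these compounds alone, 2-methoxyphenyl is the only group on the sulfonamide nitrogen so far that holds an oxygen, yet it leaves compound 4 level with the two compounds carrying a group in the 4-position of the phenyl ring: a 1.8-fold higher number from compound 3 to compound 4 (0.26 log units; within the scatter), and a 1.1-fold higher number from compound 1 to compound 4 (0.06 log units; within the scatter). Compound 2 remains the one clearly separate compound, with a 5.0-fold higher number from compound 2 to compound 4 (0.70 log units; beyond the scatter), so its 3-ethylphenyl group is the only group shown that gives a number beyond the scatter from all the others. No measurement shown bears on why these numbers fall as they do.

The compounds shown leave open whether the oxygen of the methoxy group or its place on the ring matters more, a question that 3-methoxyphenyl and 2-ethylphenyl groups could help separate. Also open, on these data alone, is how a phenyl ring carrying an amine or a carboxylic acid would behave on this nitrogen.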